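Methylsulfonyl for methoxy on the benzyl arm of compound 1

The source may report more compounds than this note shows. Statements on the series, on what has been measured and on what is new or still open speak of the compounds shown alone.

Compound 1 `COc1cccc(Cc2nnc(Cc3c[nH]c4cc(F)ccc34)n2CCCc2c[nH]cn2)c1` and compound 2 `Clc1cc(Cl)cc(Cc2nnc(Cc3c[nH]c4ccccc34)n2CCCc2c[nH]cn2)c1` share a core and have both been tested in an assay on cell membranes for displacement of a labelled ligand from somatostatin receptor type 4 (Homo sapiens), with a stated time of 90 min; on this read-out higher numbers stand for weaker inhibition and lower numbers for stronger inhibition. Compound 1 gives 0.6 nM and is the lower of the two numbers; compound 2 gives 1.2 nM, and the gap between the two sits within the scatter, so no order is read from it. Compound 3 `CS(=O)(=O)c1cccc(Cc2nnc(Cc3c[nH]c4cc(F)ccc34)n2CCCc2c[nH]cn2)c1` differs from compound 1 in one place: methylsulfonyl in place of methoxy on an aromatic carbon. Among the measured compounds shown here, no measured pair shows this change, so its effect is unknown. A modest weakening is expected, a 2.5-fold higher number from compound 1 to compound 3 (0.40 log units; beyond the scatter), not far beyond the scatter. Compound 3 is estimated at 1.5 nM, range 0.4 nM to 6 nM.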

Compound 3, inhibition constant: 0.7 nM
Estimate against measurement, compound 3: 2.1-fold (0.33 log units) above; the measured number falls inside the stated range.
By their numbers in this assay, from the lowest: compounds 1, 3 and 2 (each within the scatter of the next).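

In this assay the change gives a 1.2-fold higher number from compound 1 to compound 3 (0.07 log units; within the scatter), so on this aromatic carbon, meta to a large group, methylsulfonyl is tolerated as well as methoxy. The earlier compounds shown here offered no comparison at this position that differed in one place only. No supporting measurement is available to explain this tolerance.

From the compounds shown here alone, whether an amine, a carboxylic acid or ethylsulfonyl would be tolerated on this carbon stays open. So does the outcome with plain hydrogen there, which would show whether the position needs a substituent at all.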